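Varying the Group on the Carbonyl Carbon

The compounds below may be only part of what the source reports. "The series", "measured", "known", "first", "only" and "open" are said of these compounds alone.

Three compounds built on one shared core differ only in the group attached to a carbonyl carbon. Compound 1 `CCCC(=O)C1=C(C)NC(=O)NC1c1ccsc1` carries propyl on that carbonyl carbon, and in an assay on membranes from CHO cells for displacement of a labelled ligand from adenosine receptor A1 (Homo sapiens), read by scintillation counting, with a stated time of 60 min, tested at 1 uM (on this read-out higher numbers stand for more inhibition at the one concentration tested (going by the name of the read-out) and lower numbers for less inhibition), compound 1 gives 6%. Compound 2 `CC1=C(C(=O)NC(C)C)C(c2ccsc2)NC(=O)N1` carries isopropylamino, and in this assay compound 2 gives 8%. Compound 3 `CCSC(=O)C1=C(C)NC(=O)NC1c1ccsc1` carries ethylsulfanyl, and in this assay compound 3 gives 11%. The number for compound 3 sits within the scatter of both others: a number 5 percentage points higher from compound 1 to compound 3 (within the scatter) and a number 3 percentage points higher from compound 2 to compound 3 (within the scatter), while a number 2 percentage points higher from compound 1 to compound 2 (within the scatter) is just as small. Compound 4 `CCC(C)OC(=O)C1=C(C)NC(=O)NC1c1ccsc1` has not been measured; it differs from compound 3 in one respect: sec-butoxy in place of ethylsulfanyl on a carbonyl carbon. All three measured steps concern exchanges at the same carbonyl carbon and none of them left the scatter, so a fourth exchange there is expected to behave alike, and the step in this assay is expected to be a number 3 percentage points lower from compound 3 to compound 4 (within the scatter), with no direction beyond the scatter. Compound 4 is therefore estimated to give 8% in this assay, with a range from -5% to 22%.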

Compound 4, a percentage reported as inhibition, at one concentration (the size of the read-out at that concentration, not a potency): 5%
Compound 4: the middle estimate sits 3 percentage points above what was measured; measured number inside the range.
By their numbers in this assay, from the lowest: compounds 4, 1, 2 and 3 (each within the scatter of the next).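

In this assay, a fourth kind of group on the carbonyl carbon stays within the scatter of all three others, with a number 6 percentage points lower from compound 3 to compound 4 (within the scatter), a number 3 percentage points lower from compound 2 to compound 4 (within the scatter) and a number 1 percentage points lower from compound 1 to compound 4 (within the scatter). Sec-butoxy has 5 heavy atoms against 3 for ethylsulfanyl and carries oxygen where ethylsulfanyl carries sulfur, yet even this exchange does not separate the two compounds, so none of the four groups stands apart at the one concentration tested. Nothing available here bears on why these numbers lie so close together.

From the compounds shown here alone, it remains open whether a carboxylic acid or a longer chain such as hexyloxy on the same carbonyl carbon would leave the scatter. Also open, going by these compounds, is how these four compounds would compare at other concentrations.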